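From methoxy to fluoro on a nitro-bearing compound

A few compounds are considered here, and "the series" means these few. Any claim that something is new, unique, unknown or untested is made for them only; others in the source may bear on it.

compound 1 `COc1cc(OC)c(/C=C/S(=O)(=O)Nc2ccc(F)c(N)c2)c(OC)c1` gives 5000 nM
compound 2 `COc1cc(OC)c(/C=C/S(=O)(=O)Nc2ccc(OC)c([N+](=O)[O-])c2)c(OC)c1` gives 1000 nM

Within the data shown here, in a functional assay on K562 cells (Homo sapiens) for cytotoxicity, read by trypan blue exclusion, with a stated time of 96 h (on this read-out lower numbers stand for stronger inhibition and higher numbers for weaker inhibition), compound 2 gives 1000 nM as the lower of the two numbers so far, and compound 1 stands higher by a gap beyond the scatter. Compound 3 `COc1cc(OC)c(/C=C/S(=O)(=O)Nc2ccc(F)c([N+](=O)[O-])c2)c(OC)c1` has not yet been measured. It differs from compound 2 by fluoro in place of methoxy on an aromatic carbon ortho to a nitro group and para to a large group.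

Among the measured compounds shown here, no measured pair isolates this exchange, since compounds 1 and 2 differ in more than one place. Compound 1 carries fluoro and gives 5000 nM but has no nitro group, so it offers only a loose hint. A small move toward a higher number is therefore expected, not beyond the scatter, and the estimate is a 1.5-fold higher number from compound 2 to compound 3 (0.18 log units; within the scatter) on this read-out. For compound 3 the estimated value is 1500 nM with an expected range from 400 nM to 6000 nM in this cell test.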

Compound 3, half-maximal inhibitory concentration: 75000 nM
Compound 3: middle estimate off by 50-fold (1.70 log units), on the low side; measured number outside the range, above it.
By their numbers in this assay, from the lowest: compound 2; then compound 1; then compound 3.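

With the nitro group held fixed, fluoro in place of methoxy on this aromatic carbon, ortho to a nitro group and para to a large group, gives a 75-fold higher number from compound 2 to compound 3 (1.88 log units; beyond the scatter) in this assay, so this position responds strongly to the exchange, which the earlier pair, differing in more than one place, could not show. With fluoro held fixed, nitro in place of amino gives a 15-fold higher number from compound 1 to compound 3 (1.18 log units; beyond the scatter), so a nitro group does not by itself secure a low number in this series, and compound 3 now stands as the weakest of the three, with steps to both others beyond the scatter. Nothing measured here accounts for the size of either step, and no information on a cause is available.

The compounds shown leave open whether the large step reflects the loss of methoxy or the arrival of fluoro, a question that a hydroxyl, a chloro or an ethoxy group on the same carbon would help to separate. They also leave open whether nitro in place of amino would move the number the same way with methoxy on that carbon.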